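The source may report more compounds than this note shows. Statements on the series, on what has been measured and on what is new or still open speak of the compounds shown alone.

Compound 1 `O=C1CN(c2cc(=O)c3cc(C(F)(F)F)cc([N+](=O)[O-])c3s2)CCN1CC1CCCCC1` and compound 2 `CC1CN(c2cc(=O)c3cc(C(F)(F)F)cc([N+](=O)[O-])c3s2)CCN1CC1CCCCC1` share a core and differ in the saturated ring that carries the cyclohexylmethyl group. In an ADME assay on microsomes from liver (Homo sapiens) for metabolic stability, read by LC-MS, using NADPH, with a stated time of 30 min, tested at 1 uM (a lower number here means that less of the compound is left, a higher number that more of the compound is left), compound 1 gives 86.6%. In this assay compound 2 gives 62.7%, the lower of the two numbers, and the gap to compound 1 lies beyond the usual scatter of this kind of measurement. Going by the values given here, no single-point step between these two measured compounds is available, so only the two values themselves can be compared.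

Compound 3 `O=c1cc(N2CCN(CC3CCCCC3)CC2)sc2c([N+](=O)[O-])cc(C(F)(F)F)cc12` has not yet been measured in this assay. It differs from compound 2 in one place: hydrogen in place of methyl on a saturated ring carbon on a saturated ring carbon of a six-membered non-aromatic ring with 2 nitrogen.

Among the compounds with values here, with only two measured compounds to draw on, the step from compound 2 to compound 3 is expected to be small, a number 5.3 percentage points higher from compound 2 to compound 3 (within the scatter), and not clearly beyond the scatter. Compound 3 is accordingly estimated at 68%, with a plausible range from 48% to 85%.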

Compound 3, percent of the compound remaining: 66.7%
Estimate against measurement, compound 3: 1.3 percentage points above; low and high end bracket the measured number.
By their numbers in this assay, from the lowest: compounds 2 and 3 (each within the scatter of the next); then compound 1.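

Going by these compounds alone, compound 2 and compound 3 differ only at the saturated ring carbon next to the ring nitrogen, and this gives the first direct reading of that position: in this assay, hydrogen in place of methyl gives a number 4 percentage points higher from compound 2 to compound 3 (within the scatter). The methyl on this carbon therefore has no effect that this measurement can separate from the scatter, and the two compounds cannot be ranked against each other. Nothing available gives a reason for this result.

Going by these compounds, it remains open whether a larger or more functionalised group on this ring carbon, such as an ethyl, a hydroxymethyl or an aminomethyl group, would also stay within the scatter in this assay. The compounds shown also leave open whether the two mirror-image forms of compound 2 would read alike.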